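Moving the ring nitrogen in a pyrimidine-based inhibitor series

The source may report more compounds than this note shows. Statements on the series, on what has been measured and on what is new or still open speak of the compounds shown alone.

Measured compounds in a functional assay for inhibition, with Homo sapiens as the target; a lower number here means a stronger inhibitor, a higher number a weaker inhibitor:
compound 1, `c1ccc(-c2ccnc(Nc3cccc(OCCn4ccnc4)c3)n2)nc1`, gives 400 nM;
compound 2, `CCc1cccc(Nc2nccc(-c3ccccn3)n2)c1`, gives 1400 nM;
compound 3, `CCOC(=O)c1cccc(Nc2nccc(-c3ccccn3)n2)c1`, gives 3000 nM.

Compound 1 stands lowest of the three numbers shown. Its nearest neighbour is compound 2, reached by a 3.5-fold higher number from compound 1 to compound 2 (0.54 log units; beyond the scatter), and the furthest is compound 3, reached by a 7.5-fold higher number from compound 1 to compound 3 (0.88 log units; beyond the scatter); between those two lies a 2.1-fold higher number from compound 2 to compound 3 (0.33 log units; beyond the scatter). All three measured steps alter the group on the aromatic carbon of the anilino ring and leave the rest of the shared core of compound 1 untouched.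

Compound 4, `c1cc(Nc2nccc(-c3ccncc3)n2)cc(OCCn2ccnc2)c1`, differs from compound 1 in a different way: pyridin-4-yl in place of pyridin-2-yl on an aromatic carbon. The change sits on an aromatic carbon of the six-membered aromatic ring with 2 nitrogen, next to the ring nitrogen, meta to a large group, opposite the ring nitrogen. Within the data shown here, none of the measured steps touches this part of the molecule, so no step bears on it directly, and the size of the effect cannot be read from the three numbers at hand. On these data alone, the account therefore treats the outcome as open, with the wide range that follows, and expects a modest weakening rather than none, since the pyridin-2-yl group is shared by every measured compound and its replacement is untested. On that basis compound 4 is expected to give 1500 nM, within 300 nM to 8000 nM, meaning an expected 3.8-fold higher number from compound 1 to compound 4 (0.57 log units; beyond the scatter).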

Compound 4, half-maximal inhibitory concentration: 200 nM
Estimate against measurement, compound 4: 7.5-fold (0.88 log units) above; the measured number lies below the stated range.
By their numbers in this assay, from the lowest: compounds 4 and 1 (each within the scatter of the next); then compound 2; then compound 3.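

In this assay, putting pyridin-4-yl in place of pyridin-2-yl on the aromatic carbon of the six-membered aromatic ring with 2 nitrogen gives a 2.0-fold lower number from compound 1 to compound 4 (0.30 log units; within the scatter), so compounds 1 and 4 cannot be told apart in this assay. Among these compounds, this is the first view of this position, since compounds 1, 2 and 3 all carry pyridin-2-yl and their steps show only what happens when the other group is exchanged; for this one pair, moving the pyridine nitrogen while keeping the same atoms leaves the number within the scatter, so the pyridin-2-yl arrangement is not required to keep the number of compound 1. Nothing available here accounts for this outcome, and no reason can be offered for it.

The compounds shown leave open whether pyridin-3-yl, or a phenyl ring with no ring nitrogen at all, would also stay within the scatter of compound 1 at this position. Among the compounds shown here, they also leave open whether pyridin-4-yl would behave the same way alongside the ethyl of compound 2 or the ethoxycarbonyl of compound 3, since this exchange is seen only with 2-(1H-imidazol-1-yl)ethoxy in the molecule.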